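The source may hold more compounds than are shown below. What is called first, only, known or untested is meant among the compounds shown, and "the series" means these compounds.

Working notes on the quinone and hydroquinone pair.

Compound 1 `CNC1=C(C)C(=O)C=C(C(C)C)C1=O` carries a methylamino group on its quinone core; in a functional assay on OVCAR-8 cells (Homo sapiens) for inhibition, read by sulforhodamine B assay, with a stated time of 72 h (on this read-out higher numbers stand for weaker inhibition and lower numbers for stronger inhibition), compound 1 gives 12900 nM. Compound 2 `CCNC1=C(C)C(=O)C=C(C(C)C)C1=O` differs from compound 1 by methyl in place of hydrogen on a saturated chain carbon bound to an amine nitrogen. In this assay compound 2 gives 16000 nM, so that the step of a 1.2-fold higher number from compound 1 to compound 2 (0.09 log units; within the scatter) does not separate the two compounds.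

Compound 3 `Cc1cc(O)c(C(C)C)cc1O` is the hydroquinone with an isopropyl group; in this assay compound 3 gives 8900 nM. The difference between the core of compound 3 and the core of compound 1 is not broken down here; their values, and that of compound 2, all lie within the scatter of one another, so no order among the three is claimed.

Compound 4 `Cc1cc(O)c(C(C)(C)C)cc1O` is not yet measured. It differs from compound 3 by methyl in place of hydrogen on a saturated chain carbon bound to an aromatic carbon and two saturated chain carbons. For the measured compounds named here, this is the same kind of change as the one from compound 1 to compound 2, a methyl entering in place of a hydrogen, but the place is not the same: there the carbon was bound to an amine nitrogen, here it is bound to an aromatic carbon and two saturated chain carbons. Going by the values given here, the one measured instance of a methyl entering in place of hydrogen, the step from compound 1 to compound 2, stayed within the scatter, and nothing among the three measured compounds suggests the hydroquinone core should respond differently, so a similar outcome is expected here: the step of a 1.1-fold higher number from compound 3 to compound 4 (0.05 log units; within the scatter) is estimated to be small. Compound 4 is therefore expected to give about 10000 nM in this assay, with the estimate bounded by 4000 nM and 25000 nM.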

Compound 4, half-maximal inhibitory concentration: 12200 nM
Compound 4: the middle estimate sits 1.2-fold (0.09 log units) below what was measured; the range from low to high includes it.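

In this assay, the change from isopropyl to tert-butyl gives a 1.4-fold higher number from compound 3 to compound 4 (0.14 log units; within the scatter), so this change does not separate the two compounds. Set beside the earlier methyl step, the result on the second core shows no difference between the two cores: the same change on two cores in this assay, a 1.2-fold higher number (0.09 log units; within the scatter) from compound 1 to compound 2 and a 1.4-fold higher number (0.14 log units; within the scatter) from compound 3 to compound 4, 1.1-fold (0.04 log units) apart, within the scatter of two such steps This shows only that the change stayed small on both cores in this assay; it does not show a shared effect of the methyl that carries from one core to the other, since neither step rises above the scatter, the methyl enters at a different place on each core, and two pairs support no rule for the wider series.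

The compounds shown leave open whether a larger departure from these groups, such as a longer chain, an amine or a carboxylic acid at the same places, would give a step beyond the scatter. For the compounds shown here, no pair here differs in the core alone, so what the core itself contributes also remains open.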